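Replacing 4-acetylphenyl with pentyl in an antiproliferative series

A few compounds are considered here, and "the series" means these few. Any claim that something is new, unique, unknown or untested is made for them only; others in the source may bear on it.

Three related compounds have been tested so far. In a functional assay on IMR-32 cells (Homo sapiens) for antiproliferative activity, read by MTT assay (on this read-out lower numbers stand for stronger inhibition and higher numbers for weaker inhibition), compound 1 (`CC1(C)CCc2cc(C(=O)/C=C/c3ccc(OCc4cn(-c5ccc(Br)cc5)nn4)cc3)c(O)cc2O1`) gave 69400 nM and compound 3 (`Cc1c(-n2cc(COc3ccc(/C=C/C(=O)c4ccc5c(c4O)CCC(C)(C)O5)cc3)nn2)cccc1[N+](=O)[O-]`) gave 73500 nM as values within the usual scatter of each other. Compound 2 (`CC(=O)c1ccc(-n2cc(COc3ccc(/C=C/C(=O)c4cc5c(cc4O)OC(C)(C)CC5)cc3)nn2)cc1`) has no single number to place beside them: compound 2 was reported as "not active" (no number reported) and so has no position on the numerical scale. How far it lies from the other two cannot be read from the data.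

Compound 4 (`CCCCCn1cc(COc2ccc(/C=C/C(=O)c3cc4c(cc3O)OC(C)(C)CC4)cc2)nn1`) has not yet been measured. The structural change pentyl in place of 4-acetylphenyl on an aromatic nitrogen puts pentyl in place of 4-acetylphenyl on an aromatic nitrogen of a five-membered aromatic ring with 3 nitrogen. For the measured compounds named here, no measured pair shows what a change at this place does in this assay and the expectation is therefore loose. A modest step towards stronger inhibition is expected, from no reported number to a weak one, although compound 4 could also remain without a number. Going by the values given here, the only numerical guides are compound 1 at 69400 nM and compound 3 at 73500 nM and neither suggests strong activity. For compound 4 the estimated value is 60000 nM within an expected range of 25000 nM to 120000 nM in this estimate.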

Compound 4, half-maximal inhibitory concentration: "not active" (no number reported)
Nothing numeric was reported for compound 4; no gap can be computed for the estimate.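

For the compounds shown here, compound 2 and compound 4 both stand without a number in this assay, and no step between them can be read. Nothing in the data shown explains this result. The compounds shown leave open whether pentyl in place of 4-acetylphenyl changes inhibition at all on this read-out.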